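Swapping a methyl for a chloro on an aromatic carbon

This account rests on a few compounds, and the source may have more. Where it says the series, first, only, none or still open, it means among the compounds named here.

Compound 1 `Cc1cc(C(F)(F)F)ccc1-c1cc2cnn([C@@H](CC(C)C)c3ccc(C(=O)NCCC(=O)O)cc3)c2cc1C`: 6.5 h
Compound 2 `Cc1cc(C(F)(F)F)ccc1-c1cc2cn([C@@H](CC(C)C)c3ccc(C(=O)NCCC(=O)O)cc3)nc2cc1C`: 5 h

In an ADME assay on the whole organism (Mus musculus, strain C57) for metabolic stability, at a dose of 20 mg/kg by the oral route (on this read-out lower numbers stand for a shorter-lived compound and higher numbers for a longer-lived compound), compound 1 gives 6.5 h and compound 2 gives 5 h, two values within the usual scatter of each other. Compound 3 `Cc1cc2c(cnn2[C@@H](CC(C)C)c2ccc(C(=O)NCCC(=O)O)cc2)cc1-c1ccc(C(F)(F)F)cc1Cl` shares the core of compound 1 and differs in one place: chloro in place of methyl on an aromatic carbon. Put another way, 2-methyl-4-(trifluoromethyl)phenyl becomes 2-chloro-4-(trifluoromethyl)phenyl. For the measured compounds named here, no measured pair shows this change, so the data offer no direct guide to its size or direction. The estimated step in this assay is a 1.1-fold lower number from compound 1 to compound 3 (0.03 log units; within the scatter), which is expected to stay within the scatter. For compound 3 the estimate is 6 h, with an expected range from 3.2 h to 11 h.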

Compound 3, half-life: 9.1 h
The estimate for compound 3 lay 1.5-fold (0.18 log units) below the measured number; low and high end bracket the measured number.
By their numbers in this assay, from the lowest: compounds 2, 1 and 3 (each within the scatter of the next).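

In this assay, for the compounds shown here, the first measured pair for this swap gives a 1.4-fold higher number from compound 1 to compound 3 (0.15 log units; within the scatter). On this aromatic carbon, then, chloro can stand in place of methyl without a step in half-life that exceeds the usual scatter. No measurement at hand explains this result. As far as these compounds go, whether a fluorine atom, a methoxy group or a nitrile on the same carbon would fit as well remains open. So does whether the same swap would give a similar result on compound 2.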